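Chloro for methyl: stability on human liver microsomes

The source may report more compounds than this note shows. Statements on the series, on what has been measured and on what is new or still open speak of the compounds shown alone.

Compound 1 `Cc1cccc(Cl)c1C(=O)c1cn(-c2ccc(C(=O)O)cc2F)c2ncccc12` was measured in an ADME assay on microsomes from liver (Homo sapiens) for metabolic stability, read by LC-MS, using NADPH, with stated times of 5 min and 30 min, tested at 1 uM (on this read-out higher numbers stand for a more stable compound and lower numbers for a less stable compound), and gave 88%. Among the three measured compounds this is the lowest number. Compound 3 `O=C(O)c1ccc(-n2cc(C(=O)c3c(Cl)cccc3Cl)c3ncccc32)cc1` gives 94% in this assay, a value that lies within the usual scatter of that of compound 1. Compound 2 `O=C(O)c1ccc(-n2cc(C(=O)c3c(Cl)cccc3Cl)c3cccnc32)cc1` gives 100% in this assay, a number that stands beyond the scatter above compound 1.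

The account now moves to compound 4 `O=C(O)c1ccc(-n2cc(C(=O)c3c(Cl)cccc3Cl)c3cccnc32)c(F)c1`, which has not yet been measured. It differs from compound 1 in one place: chloro in place of methyl on an aromatic carbon. No step between two measured compounds that differ in exactly this way is available, so the size of the change can only be judged from the three numbers shown.

Because compound 2 stands at 100% and compound 3 at 94%, both higher than compound 1, a modest upward step is expected in this assay, roughly a number 6 percentage points higher from compound 1 to compound 4 (within the scatter), which would stay within the scatter. Compound 4 is therefore estimated to give 94% in this assay, with a range from 82% to 100%.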

Compound 4, percent of the compound remaining in the Homo sapiens assay: 100%
The estimate for compound 4 lay 6 percentage points below the measured number; low and high end bracket the measured number.
By their numbers in the Homo sapiens assay, from the lowest: compounds 1, 3, 2 and 4 (each within the scatter of the next, the first and the last beyond it).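

In the Homo sapiens assay, chloro in place of methyl on an aromatic carbon, read as 2-chloro-6-methylphenyl to 2,6-dichlorophenyl, now has a measured size, a number 12 percentage points higher from compound 1 to compound 4 (beyond the scatter), whereas fluoro in place of hydrogen on an aromatic carbon gives no change at the digits printed from compound 2 to compound 4 (within the scatter). In a physicochemical assay for solubility, at pH 4 (on this read-out lower numbers stand for lower solubility and higher numbers for higher solubility), compound 1 gives 1000 nM. In the physicochemical assay compound 4 gives < 1000 nM, which is a limit of the assay and not a number, and the step to this compound cannot be read because of that limit: the limit of < 1000 nM in the physicochemical assay, at which 1 of the 2 values shown sits.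

The chloro for methyl step rests on this one pair of compounds, so the compounds shown leave open whether it would hold on another core, and how a methoxy or a trifluoromethyl group at the same place would compare with chloro and methyl. They also leave open how either read-out would respond if the carboxylic acid shared by all four compounds gave way to a primary amide or a tetrazole.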